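The source may report more compounds than this note shows. Statements on the series, on what has been measured and on what is new or still open speak of the compounds shown alone.

In an ADME assay on MRC5 cells (Homo sapiens) for cytotoxicity, read by neutral red uptake, with a stated time of 24 h (a higher number here means a weaker inhibitor, a lower number a stronger inhibitor), compound 1 (`CC(=O)Oc1c(C(C)C)cc2c3c1OC(=O)[C@@]31CCCC(C)(C)[C@@H]1CC2`) gives 290000 nM and sits high among the three measured compounds, within the scatter of compound 3 (`CC(C)c1cc2c3c(c1OC(=O)c1ccccc1)OC(=O)[C@@]31CCCC(C)(C)[C@@H]1CC2`) at 512000 nM and clear of compound 2 (`CCC(=O)Oc1c(C(C)C)cc2c3c1OC(=O)[C@@]31CCCC(C)(C)[C@@H]1CC2`) at 125000 nM on the lower side. Compound 4 (`CC(C)c1cc2c3c(c1OC(=O)c1cccnc1)OC(=O)[C@@]31CCCC(C)(C)[C@@H]1CC2`) has pyridin-3-yl in place of methyl on a carbonyl carbon. The nearest measured change, phenyl in place of methyl, is a 1.8-fold higher number from compound 1 to compound 3 (0.25 log units; within the scatter) and so no step beyond the scatter is expected in this assay for the new compound. The modest steps of a 2.3-fold lower number from compound 1 to compound 2 (0.37 log units; beyond the scatter) and a 4.1-fold higher number from compound 2 to compound 3 (0.61 log units; beyond the scatter) both involve the ethyl group of compound 2 and bear less directly. The estimated change is a 1.2-fold higher number from compound 1 to compound 4 (0.08 log units; within the scatter) and no more. For compound 4 the expected value is 350000 nM within a range of 150000 nM to 800000 nM as estimated here.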

Compound 4, half-maximal inhibitory concentration: 296000 nM
Estimate against measurement, compound 4: 1.2-fold (0.07 log units) above; the measured number falls inside the stated range.
By their numbers in this assay, from the lowest: compound 2; then compounds 1, 4 and 3 (each within the scatter of the next).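

In this assay, pyridin-3-yl on this carbonyl carbon gives a reading within the scatter of both the methyl compound (a 1.0-fold higher number from compound 1 to compound 4 (0.01 log units; within the scatter)) and the phenyl compound (a 1.7-fold lower number from compound 3 to compound 4 (0.24 log units; within the scatter)), so neither the ring nitrogen nor the aromatic ring separates these compounds. Compound 2, with its ethyl group, stays apart from this new compound as well (a 2.4-fold higher number from compound 2 to compound 4 (0.37 log units; beyond the scatter)). No supporting data explain these readings. The compounds shown leave open whether pyridin-2-yl or pyridin-4-yl would read like pyridin-3-yl. They also leave open how an amine, a carboxylic acid or a chain longer than ethyl would read here.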